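The source may report more compounds than this note shows. Statements on the series, on what has been measured and on what is new or still open speak of the compounds shown alone.

Among the measured compounds shown here, compound 1 `CC(C)(C)NC(=O)c1ccc(Oc2ccc(CC(=O)O)cc2Cl)c(NS(=O)(=O)c2ccc(Cl)cc2Cl)c1` is one of only two compounds measured in an assay on HEK293 cells (plasma) for displacement of a labelled ligand from prostaglandin D2 receptor 2 (Homo sapiens), read by scintillation counting, in the presence of a further agent that is not named here (on this read-out higher numbers stand for weaker inhibition and lower numbers for stronger inhibition), where compound 1 gives 12 nM. The other, compound 2 `CCCCNC(=O)c1ccc(Oc2ccc(CC(=O)O)cc2F)c(NS(=O)(=O)c2ccc(Cl)cc2Cl)c1`, differs from compound 1 in more than one place, so no single step can be read between them; in this assay compound 2 gives 110 nM, and the gap between the two values lies beyond the usual scatter, which leaves compound 1 with the lower of the two numbers. Compound 3 `O=C(O)Cc1ccc(Oc2ccc(C(=O)NC3CCC3)cc2NS(=O)(=O)c2ccc(Cl)cc2Cl)c(Cl)c1` has not yet been measured. It comes from compound 1 by one change: cyclobutyl in place of tert-butyl on an amide-type nitrogen. For the measured compounds named here, no measured pair shows this change alone, so there is no step to copy. Exchanging one group for another of like size, with no change in donors, acceptors or charge, is expected to move the number little, if at all beyond the scatter. The expected step is small: a 1.3-fold higher number from compound 1 to compound 3 (0.12 log units; within the scatter). For compound 3 the estimate in this assay is 16 nM, within a range from 5 nM to 50 nM.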

Compound 3, half-maximal inhibitory concentration: 19 nM
For compound 3 the middle estimate is 1.2-fold (0.07 log units) below the measured one, and the stated range covers the measured number.
By their numbers in this assay, from the lowest: compounds 1 and 3 (each within the scatter of the next); then compound 2.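

In this assay the step is a 1.6-fold higher number from compound 1 to compound 3 (0.20 log units; within the scatter), and this is the only comparison shown in which a single place differs. It shows that this amide-type nitrogen can carry cyclobutyl, a closed ring, as well as tert-butyl, an open branched group with the same count of heavy atoms, without the two compounds being distinguishable on this read-out. Closing the group into a ring is therefore tolerated here, at least for this pair.

The compounds shown leave open whether a smaller ring such as cyclopropyl, a larger one such as cyclohexyl, or a ring containing an oxygen atom would also be tolerated on this nitrogen. No measurement shown speaks to why tert-butyl and cyclobutyl read alike.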